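Halogen swap at the pendant phenyl ring of the amidoxime series

The source may hold more compounds than are shown below. What is called first, only, known or untested is meant among the compounds shown, and "the series" means these compounds.

Within the data shown here, compound 2 `O=[N+]([O-])c1ccc(N/C(=N\O)c2cccc(F)c2)c2nonc12` is the stronger of the two measured members in an assay on isolated protein for inhibition of Indoleamine 2,3-dioxygenase 1 (Homo sapiens), read by spectrophotometry, with a stated time of 1 h; a higher number here means a weaker inhibitor, a lower number a stronger inhibitor: compound 2 gives 75 nM, while the methyl analogue compound 1 `Cc1cccc(/C(=N/O)Nc2ccc([N+](=O)[O-])c3nonc23)c1` gives 163 nM. Among the measured compounds shown here, the one measured step, a 2.2-fold lower number from compound 1 to compound 2 (0.34 log units; beyond the scatter), is the only information available on substitution at this ring position.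

Compound 3 `O=[N+]([O-])c1ccc(N/C(=N\O)c2cccc(Cl)c2)c2nonc12` carries the change (chloro in place of fluoro on an aromatic carbon). For the measured compounds named here, no measured pair shows a fluoro-to-chloro exchange, so the step from compound 1 to compound 2 bears on it only in that it concerns the same aromatic carbon and shows the assay responds to what sits there. Going by the values given here, that step was modest and beyond the scatter; with no direct precedent, the halogen exchange is expected to move the number little, and a step that stays within the scatter is the default reading.

On that basis compound 3 is expected to give about 65 nM, with a range of 25 nM to 170 nM, meaning an expected step of a 1.2-fold lower number from compound 2 to compound 3 (0.06 log units; within the scatter).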

Compound 3, half-maximal inhibitory concentration: 184 nM
Compound 3: middle estimate off by 2.8-fold (0.45 log units), on the low side; the whole stated range lies below it.
By their numbers in this assay, from the lowest: compound 2; then compounds 1 and 3 (each within the scatter of the next).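

In this assay, the exchange of halogen at this aromatic carbon is not neutral: chloro in place of fluoro gives a 2.5-fold higher number from compound 2 to compound 3 (0.39 log units; beyond the scatter), so this position distinguishes between the two halogens, which the earlier pair could not show. Chloro in place of methyl gives a 1.1-fold higher number from compound 1 to compound 3 (0.05 log units; within the scatter), so these two groups cannot be told apart here, and the earlier gain from methyl to fluoro does not extend to chloro; among these three compounds, compound 2 alone stands apart as the strongest, with its steps to both others beyond the scatter. Nothing available explains why fluoro reads differently from chloro and methyl at this carbon.

The compounds shown leave open how plain hydrogen, bromo, methoxy or a nitrile would read at this carbon, and therefore whether fluoro is an isolated favourable case or part of a wider trend. They also leave open whether fluoro would keep its lead over chloro and methyl on other carbons of the same ring.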